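The source may report more compounds than this note shows. Statements on the series, on what has been measured and on what is new or still open speak of the compounds shown alone.

Measured in an ADME assay on HEK-293T cells (Homo sapiens) for inhibition, read by CCK-8 assay, with a stated time of 48 h, tested at 20 uM; on this read-out higher numbers stand for more inhibition of growth at the one concentration tested and lower numbers for less inhibition of growth:

- compound 1 `N#C/C(=C\c1ccccc1OS(=O)(=O)c1ccccc1[N+](=O)[O-])C(=O)Nc1nnc(Cc2ccc(F)cc2)s1`: 6%
- compound 2 `N#C/C(=C\c1ccccc1OS(=O)(=O)c1ccccc1[N+](=O)[O-])C(=O)Nc1nnc(Cc2ccc(Cl)cc2)s1`: 20%
- compound 3 `N#C/C(=C\c1ccccc1OS(=O)(=O)c1ccc(Cl)cc1)C(=O)Nc1nnc(Cc2ccc(Cl)cc2)s1`: 14%

For the measured compounds named here, compound 2 stands clearly apart from only one of its neighbours. The change a number 14 percentage points higher from compound 1 to compound 2 (beyond the scatter) is a modest step, while the change a number 6 percentage points lower from compound 2 to compound 3 (within the scatter) stays within the scatter, so compound 2 and compound 3 cannot be told apart.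

Compound 4 `Cc1ccc(Cc2nnc(NC(=O)/C(C#N)=C/c3ccccc3OS(=O)(=O)c3ccccc3[N+](=O)[O-])s2)cc1` is not yet measured. It differs from compound 2 by methyl in place of chloro on an aromatic carbon. The closest guide is the step of a number 14 percentage points higher from compound 1 to compound 2 (beyond the scatter), where chloro replaced fluoro on an aromatic carbon. The step of a number 6 percentage points lower from compound 2 to compound 3 (within the scatter) changes the other end of the molecule and says little here. Going by the values given here, with one modest step as the only guide, a shift beyond the scatter is not expected in this assay, and a slight fall is the likeliest direction. The expected change is a number 6 percentage points lower from compound 2 to compound 4 (within the scatter). For compound 4 the estimated value is 14%, with an expected range from 3% to 28%.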

Compound 4, percent growth inhibition at one concentration: 6%
The estimate for compound 4 lay 8 percentage points above the measured number; the range from low to high includes it.
By their numbers in this assay, from the lowest: compounds 1, 4, 3 and 2 (each within the scatter of the next, the first and the last beyond it).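

In this assay, putting methyl in place of chloro, which turns the 4-chlorobenzyl group into 4-methylbenzyl, gives a number 14 percentage points lower from compound 2 to compound 4 (beyond the scatter), while putting methyl in place of fluoro gives no change at the digits printed from compound 1 to compound 4 (within the scatter). At this position, chloro therefore stands apart from two different groups, whereas fluoro and methyl cannot be told apart, so the earlier gain seen with chloro is not specific to a comparison with fluoro. Nothing measured here explains why chloro differs from the other two groups.

As far as these compounds go, it remains open whether bromo, methoxy or trifluoromethyl at this position would match chloro or fall with fluoro and methyl. It is also unknown whether the gap between these groups would persist with 4-chlorophenyl in place of 2-nitrophenyl on the sulfonyl sulfur.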